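Adding a Methylsulfanyl Group to a Bare Ring Carbon

The compounds below may be only part of what the source reports. "The series", "measured", "known", "first", "only" and "open" are said of these compounds alone.

Compound 1, `CCOc1nc(N)c2nc(O)n(Cc3ccccc3)c2n1`: 0.3 mg/kg
Compound 2, `Nc1ncnc2c1nc(O)n2Cc1ccccc1`: 30 mg/kg
Compound 3, `CSc1nc(N)c2nc(O)n(Cc3ccccc3)c2n1`: not yet measured

All three compounds belong to a functional assay on the whole organism for activation, with Mus musculus as the target; on this read-out lower numbers stand for an effect already at smaller amounts and higher numbers for an effect only at larger amounts of compound. Among the two measured numbers, compound 2 stands highest with 30 mg/kg, and its nearest neighbour is compound 1 with 0.3 mg/kg. Among the measured compounds shown here, only one measured step exists, and it bears directly on the change at hand: a 100-fold higher number from compound 1 to compound 2 (2.00 log units; beyond the scatter). Compound 3 differs from compound 2 by methylsulfanyl in place of hydrogen on an aromatic carbon, at the same aromatic carbon that carries the ethoxy group in compound 1. Since the step from compound 1 to compound 2 shows that leaving this carbon bare raises the number strongly, placing a group back on it is expected to lower the number. A methylsulfanyl group is not an ethoxy group, so a complete reversal is not assumed. The expected step for compound 3 is a 30-fold lower number from compound 2 to compound 3 (1.48 log units; beyond the scatter). Compound 3 is therefore estimated at 1 mg/kg, with a range from 0.3 mg/kg to 10 mg/kg.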

Compound 3, minimum effective dose: 0.1 mg/kg
Compound 3: the middle estimate sits 10-fold (1.00 log units) above what was measured; the whole stated range lies above it.
By their numbers in this assay, from the lowest: compound 3; then compound 1; then compound 2.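

In this assay, among the compounds shown here, ethoxy is not the only group that pays off on this aromatic carbon between two ring nitrogen atoms: methylsulfanyl on the bare position gives a 300-fold lower number from compound 2 to compound 3 (2.48 log units; beyond the scatter), so the large gain does not depend on ethoxy alone. Methylsulfanyl also goes past ethoxy here, with a 3.0-fold lower number from compound 1 to compound 3 (0.48 log units; beyond the scatter), a modest step but one that lies beyond the scatter. Nothing available here accounts for either difference.

The compounds shown carry only hydrogen, ethoxy or methylsulfanyl on this carbon, so it remains open how a butylamino group or a longer chain such as butylsulfanyl would fare. Methoxy would be especially telling, since comparing it with methylsulfanyl would test whether having sulfur rather than oxygen on this carbon changes the number.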